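The compounds below may be only part of what the source reports. "The series", "measured", "known", "first", "only" and "open" are said of these compounds alone.

Compound 3 `Cc1ccc([C@H]2CC[C@@H](C(=O)O)N2C(=O)CNC(=O)[C@@H](S)Cc2ccc(O)cc2)cc1` sits in the middle of the three compounds measured in an assay on isolated protein for inhibition of Neprilysin (Oryctolagus cuniculus); on this read-out higher numbers stand for weaker inhibition and lower numbers for stronger inhibition: compound 3 gives 5.5 nM. Its nearest neighbour is compound 2 `Cc1ccccc1[C@@H]1CC[C@@H](C(=O)O)N1C(=O)CNC(=O)[C@@H](S)Cc1ccccc1`, which in this assay gives 17 nM, a weaker result that lies beyond the scatter. The strongest of the three is compound 1 `O=C(NCC(=O)N1[C@@H](c2ccccc2O)CC[C@H]1C(=O)O)[C@@H](S)Cc1ccccc1`, which in this assay gives 1 nM.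

Compound 4 `O=C(NCC(=O)N1[C@@H](c2cccc(O)c2)CC[C@H]1C(=O)O)[C@@H](S)Cc1ccc(O)cc1` has not yet been measured. Compared with compound 3, the change is 3-hydroxyphenyl in place of 4-methylphenyl on a saturated ring carbon, in words: 3-hydroxyphenyl in place of 4-methylphenyl on a saturated ring carbon. The thiol side of compound 4 carries the same 4-hydroxyphenyl as compound 3.

Among the measured compounds, the one that carries a hydroxyphenyl on the ring carbon, compound 1 with 1 nM, is stronger in this assay than the two that carry a methylphenyl there, so a gain for compound 4 is the expectation, though the hydroxy here sits differently and the thiol side differs as well, so a modest step is expected. The estimate for compound 4 in this assay is 2.5 nM, in a range from 0.8 nM to 8 nM. This estimate means an expected step of a 2.2-fold lower number from compound 3 to compound 4 (0.34 log units; beyond the scatter).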

Compound 4, half-maximal inhibitory concentration: 1.6 nM
Compound 4: the middle estimate sits 1.6-fold (0.19 log units) above what was measured, and the stated range covers the measured number.
By their numbers in this assay, from the lowest: compounds 1 and 4 (each within the scatter of the next); then compound 3; then compound 2.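

Going by these compounds alone, compounds 3 and 4 are the first pair here that differ in one place, and with the thiol side held the same, the swap on the saturated ring carbon gives a 3.4-fold lower number from compound 3 to compound 4 (0.54 log units; beyond the scatter) in this assay. Within the data shown here, this shows that the group at this position can shift the result beyond the scatter, which the earlier compounds, each differing in more than one place, could not show on their own. The change replaces methyl with hydroxy and also moves the substituent on the phenyl ring, and no measurement here explains the step.

The compounds shown do not separate the effect of the hydroxy from the effect of where it sits on the phenyl ring. A methyl group or an amine carried exactly where compound 4 carries its hydroxy would address that question.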